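Thiazole amide replaces methylcyclohexyl in a thiazolopyridine series

A few compounds are considered here, and "the series" means these few. Any claim that something is new, unique, unknown or untested is made for them only; others in the source may bear on it.

Three amides sharing one core have been measured in an assay on HEK293 cells for positive allosteric modulation of metabotropic glutamate receptor 5 (Homo sapiens), read by FLIPR, with a stated time of 1 h; on this read-out lower numbers stand for an effect already at smaller amounts and higher numbers for an effect only at larger amounts of compound. Compound 1 `O=C(C1CCCC1)N1CCc2nc(C#Cc3ccccc3)sc2C1` gives 19 nM, compound 2 `O=C(C1CCCCC1)N1CCc2nc(C#Cc3ccccc3)sc2C1` gives 167 nM, and compound 3 `CC1CCC(C(=O)N2CCc3nc(C#Cc4ccccc4)sc3C2)CC1` gives 190 nM. Compound 3 thus shows the highest of the three numbers: compound 2 lies within the scatter of it, as a 1.1-fold higher number from compound 2 to compound 3 (0.06 log units; within the scatter) shows, whereas compound 1 lies beyond it, with a 10-fold higher number from compound 1 to compound 3 (1.00 log units; beyond the scatter).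

Compound 4 `Cc1nc(C(=O)N2CCc3nc(C#Cc4ccccc4)sc3C2)cs1` differs from compound 3 by 2-methyl-1,3-thiazol-4-yl in place of 4-methylcyclohexyl on a carbonyl carbon. Within the data shown here, the steps that bear on this place are an 8.8-fold higher number from compound 1 to compound 2 (0.94 log units; beyond the scatter) and a 10-fold higher number from compound 1 to compound 3 (1.00 log units; beyond the scatter), which show that the group on the carbonyl carbon can move this assay markedly, while a 1.1-fold higher number from compound 2 to compound 3 (0.06 log units; within the scatter) shows that a methyl on the saturated ring alone changes little. Among the measured compounds shown here, no measured step swaps the saturated ring for an aromatic ring with hetero atoms, so the direction is uncertain. Compound 4 is therefore expected to land near compound 3 with a wide range, an estimated step of a 2.1-fold lower number from compound 3 to compound 4 (0.32 log units; beyond the scatter), giving an expected 90 nM between 15 nM and 600 nM.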

Compound 4, half-maximal effective concentration: 220 nM
For compound 4 the middle estimate is 2.4-fold (0.39 log units) below the measured one; the measured number falls inside the stated range.
By their numbers in this assay, from the lowest: compound 1; then compounds 2, 3 and 4 (each within the scatter of the next).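

In this assay, 2-methyl-1,3-thiazol-4-yl on the carbonyl carbon gives a 1.2-fold higher number from compound 3 to compound 4 (0.06 log units; within the scatter) when it replaces 4-methylcyclohexyl and a 1.3-fold higher number from compound 2 to compound 4 (0.12 log units; within the scatter) when it replaces cyclohexyl, so at this place a five-membered aromatic ring with 2 hetero atoms reads the same as either six-membered carbon ring. Against cyclopentyl the same group gives a 12-fold higher number from compound 1 to compound 4 (1.06 log units; beyond the scatter), which leaves compound 1 as the only one of the four set apart from the others by a step beyond the scatter. No measurement at hand offers a reason for these numbers.

From the compounds shown here alone, it remains open whether the methyl on the thiazole matters, which the unsubstituted 1,3-thiazol-4-yl group would address. Also open, going by these compounds, is whether other small rings on the carbonyl carbon, such as cyclobutyl or tetrahydrofuranyl, would match compound 1 or compound 4.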